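This account rests on a few compounds, and the source may have more. Where it says the series, first, only, none or still open, it means among the compounds named here.

Measured compounds in an ADME assay on A549 cells (Homo sapiens) for cytotoxicity, read by resazurin assay, with a stated time of 48 h; on this read-out higher numbers stand for lower toxicity in this test and lower numbers for higher toxicity in this test:
compound 1 `CC(C)CNc1ccc(NC(=O)c2cc(Cl)ccc2O)c(Cl)c1`: 60000 nM
compound 2 `O=C(Nc1ccc(NCc2ccccc2)cc1Cl)c1cc(Cl)ccc1O`: 19700 nM
compound 3 `O=C(Nc1ccc(NCc2cccc(C(F)(F)F)c2)cc1Cl)c1cc(Cl)ccc1O`: 13300 nM

Compound 1 stands highest of these three numbers. Its nearest neighbour is compound 2, with a 3.0-fold lower number from compound 1 to compound 2 (0.48 log units; beyond the scatter), and its furthest is compound 3, with a 4.5-fold lower number from compound 1 to compound 3 (0.65 log units; beyond the scatter). Between the two aromatic analogues the step is a 1.5-fold lower number from compound 2 to compound 3 (0.17 log units; within the scatter), so nothing separates them on this read-out.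

Compound 4 `O=C(Nc1ccc(NCc2ccc(O)cc2)cc1Cl)c1cc(Cl)ccc1O` has not yet been measured in this assay. Relative to compound 1 the change is 4-hydroxyphenyl in place of isopropyl on a saturated chain carbon bound to a nitrogen on an aromatic ring; cut one bond further out it reads isobutylamino to (4-hydroxybenzyl)amino. For the measured compounds named here, the steps that bear on it are the two that already replace isopropyl at the same place with an aromatic ring, a 3.0-fold lower number from compound 1 to compound 2 (0.48 log units; beyond the scatter) and a 4.5-fold lower number from compound 1 to compound 3 (0.65 log units; beyond the scatter): both modest, both beyond the scatter, both in the same direction. Going by the values given here, the hydroxyl carried by the ring in compound 4 has no counterpart among the measured compounds, so its own contribution is unknown. On that basis a downward step of similar size is expected, a 2.4-fold lower number from compound 1 to compound 4 (0.38 log units; beyond the scatter). Compound 4 is accordingly estimated at 25000 nM in this assay, with a range from 10000 nM to 60000 nM. The measured number will settle this.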

Compound 4, half-maximal cytotoxic concentration: 116000 nM
For compound 4 the middle estimate is 4.6-fold (0.67 log units) below the measured one, and the stated range ends below it.
By their numbers in this assay, from the lowest: compounds 3 and 2 (each within the scatter of the next); then compounds 1 and 4 (each within the scatter of the next).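

In this assay, hydroxy in place of hydrogen on the aromatic ring gives a 5.9-fold higher number from compound 2 to compound 4 (0.77 log units; beyond the scatter), so an aromatic ring at this place does not on its own go with the lower numbers seen for compound 2 and compound 3. The replacement of isopropyl by 4-hydroxyphenyl gives a 1.9-fold higher number from compound 1 to compound 4 (0.29 log units; within the scatter), which does not separate the two compounds, while the change from 3-(trifluoromethyl)phenyl to 4-hydroxyphenyl gives an 8.7-fold higher number from compound 3 to compound 4 (0.94 log units; beyond the scatter); at this place, what the ring carries therefore matters at least as much as the change from isopropyl to a ring. No measurement shown here accounts for the effect of the hydroxy group on this read-out.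

As far as these compounds go, it remains open whether the higher number is specific to the hydroxy group or would also appear with a methoxy group, an amine or a carboxylic acid on the same ring. Also open, from the compounds shown here alone, is how a longer chain in place of the isobutyl or 4-hydroxybenzyl group would read in this assay.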